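Replacing fluoro with cyano at the top of the range

The source may hold more compounds than are shown below. What is called first, only, known or untested is meant among the compounds shown, and "the series" means these compounds.

Of the compounds shown here, three have been measured in an ADME assay on microsomes from liver (Rattus norvegicus) for metabolic stability, with a stated time of 10 min; a higher number here means that more of the compound is left, a lower number that less of the compound is left. In that test, compound 1 `FC(F)(F)c1ccccc1-c1ccc2[nH]c(C3=NCC4(CCCCC4)O3)nc2c1` gives 32%, compound 2 `FC(F)Oc1ccccc1-c1ccc2[nH]c(C3=NOC4(CCCCC4)C3)nc2c1` gives 59%, and compound 3 `Fc1cc(-c2ccccc2C(F)(F)F)cc2nc(C3=NOC4(CCCCC4)C3)[nH]c12` gives 100%. Compound 3 is the highest of the three, and the other two lie below it by more than the scatter.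

Compound 4 `N#Cc1cc(-c2ccccc2C(F)(F)F)cc2nc(C3=NOC4(CCCCC4)C3)[nH]c12` differs from compound 3 in one place: cyano in place of fluoro on an aromatic carbon. This puts cyano in place of fluoro on an aromatic carbon, ortho to a fused ring and meta to a 2-(trifluoromethyl)phenyl group.

Going by the values given here, no two measured compounds differ in a single place, so no measured step shows what this kind of change does. The expectation rests mainly on compound 3 at 100%, a value that leaves room for movement in only one direction. A moderate fall is expected, and the estimated change is a number 15 percentage points lower from compound 3 to compound 4 (beyond the scatter). For compound 4 the estimated value in this assay is 85%, within an expected range from 60% to 100%.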

Compound 4, percent of the compound remaining: 96%
The estimate for compound 4 lay 11 percentage points below the measured number, within the range that was stated.
By their numbers in this assay, from the lowest: compound 1; then compound 2; then compounds 4 and 3 (each within the scatter of the next).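

Going by these compounds alone, the swap of fluoro for cyano gives the first step between compounds that differ in one place: in this assay it amounts to a number 4 percentage points lower from compound 3 to compound 4 (within the scatter) and so lies within the scatter. Within the data shown here, at this aromatic carbon, ortho to a fused ring and meta to a 2-(trifluoromethyl)phenyl group, the test therefore does not separate the two groups, something the earlier compounds, which differ in more than one place, could not show. No measurement at hand bears on the reason for this result.

This single pair does not say how other groups would behave at the same carbon, such as an amine, a methoxy group or a carboxylic acid. It also leaves open whether cyano would give a similar reading on a compound with a lower value, as both members of this pair stand near the top of the range.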